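This account rests on a few compounds, and the source may have more. Where it says the series, first, only, none or still open, it means among the compounds named here.

- Compound 1 `Cc1cnc(NC(=O)c2cc(Oc3cnc(C(=O)N4CCCC4)cn3)c3cc(C)oc3c2)cn1`: < 8.1 mL/min/kg, a limit
- Compound 2 `Cc1cc2c(Oc3cnc(C(=O)N4CC(C)(C)C4)cn3)cc(C(=O)Nc3cnccn3)cc2o1`: 21.2 mL/min/kg

Among the compounds with values here, in an ADME assay (liver) for metabolic stability, with Liver microsome (Homo sapiens) as the target, using microsomes (on this read-out lower numbers stand for slow clearance and higher numbers for fast clearance), compound 2 gives 21.2 mL/min/kg, the only actual number so far. Compound 1 is reported only as a limit, < 8.1 mL/min/kg.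

Compound 3 `Cc1cc2c(Oc3cnc(C(=O)N4CC(C)(O)C4)cn3)cc(C(=O)Nc3cnccn3)cc2o1` has hydroxy in place of methyl on a saturated ring carbon, turning 3,3-dimethylazetidin-1-yl into 3-hydroxy-3-methylazetidin-1-yl (hydroxy in place of methyl on a saturated ring carbon). Within the data shown here, no measured pair shows this change, so the forecast is uncertain: a modest fall in clearance, near the edge of the usual scatter. The expected change is a 2.1-fold lower number from compound 2 to compound 3 (0.33 log units; beyond the scatter). For compound 3 the estimated clearance is 10 mL/min/kg, with an expected range of 5 mL/min/kg to 20 mL/min/kg.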

Compound 3, clearance: < 8 mL/min/kg
Compound 3 gave a limit, no number; the forecaster's own chance of this, stated with the estimate: 35%; at least 1.2-fold (0.09 log units) between middle value and limit.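

Changing 3,3-dimethylazetidin-1-yl to 3-hydroxy-3-methylazetidin-1-yl gives an at least 2.6-fold lower number from compound 2 to compound 3 (0.42 log units; beyond the scatter) in this assay, the only measured step shown at this saturated ring carbon. Compound 3 is reported only as a limit, < 8 mL/min/kg. The full size of the step therefore cannot be read, only its minimum.

Going by these compounds, the actual clearance of compound 3 remains open, as does whether the step would hold on a different core. On these data alone, it is also open whether an amine or a fluorine on the same ring carbon would match hydroxy.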